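A few compounds are considered here, and "the series" means these few. Any claim that something is new, unique, unknown or untested is made for them only; others in the source may bear on it.

Measured compounds:

compound 1 `COc1cc(C)cc(-c2nn(CC#N)cc2-c2ccc(-c3cccc(C(C)=O)c3)nc2)c1`, 87%
compound 2 `Cc1cc(O)cc(-c2nn(CC#N)cc2-c2ccnc(-c3ccc(Oc4ccccc4)cc3)c2)c1`, 86%
compound 3 `COc1cc(C)cc(-c2nn(CC#N)cc2-c2ccnc(-c3ccc(N(C)C)cc3)c2)c1`, 2%

All three were tested in a functional assay on DU-145 cells (Homo sapiens) for cytotoxicity, read by sulforhodamine B assay, with a stated time of 48 h, tested at 100 nM; a higher number here means a weaker effect of the compound at the concentration tested, a lower number a stronger effect. Compound 1 gives 87% and compound 2 gives 86%, two numbers that lie within the scatter of each other. Compound 3 stands apart: its value of 2% is the lowest of the three. Its nearest neighbour is compound 2, whose number is higher by a margin beyond the scatter, and the furthest is compound 1, higher still, also beyond the scatter. Compound 3 is therefore the strongest of the three in this assay.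

The next compound, compound 4 `Cc1cc(O)cc(-c2nn(CC#N)cc2-c2ccnc(-c3ccc(N(C)C)cc3)c2)c1`, keeps everything of compound 3 except one spot:

hydrogen in place of methyl on an oxygen on an aromatic ring

Among the measured compounds shown here, no pair among the measured compounds differs in exactly this way, so the size of such a step in this assay is not known from the data. Compound 2 also carries the 3-hydroxy-5-methylphenyl group, but differs from compound 4 elsewhere as well, so its value cannot be read as a guide. With only the value of compound 3, namely 2%, as an anchor, the expectation is a step of a number 10 percentage points higher from compound 3 to compound 4 (within the scatter), modest and towards a weaker effect, possibly none beyond the scatter. Compound 4 is estimated at 12%, with a range from 1% to 55%.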

Compound 4, a percentage reported as activity, at one concentration (the size of the read-out at that concentration, not a potency): 94%
Estimate against measurement, compound 4: 82 percentage points below, and the stated range ends below it.
By their numbers in this assay, from the lowest: compound 3; then compounds 2, 1 and 4 (each within the scatter of the next).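

In this assay the position on the oxygen proves highly sensitive: methoxy to hydroxy, the loss of a single methyl, gives a number 92 percentage points higher from compound 3 to compound 4 (beyond the scatter) and so removes nearly all of the strong effect seen for compound 3. With the hydroxy group in place, dimethylamino in place of phenoxy on an aromatic carbon gives a number 8 percentage points higher from compound 2 to compound 4 (within the scatter), so in this pair that swap makes no difference beyond the scatter, and the dimethylamino group, which compound 3 and compound 4 share, does not bring the strong effect without the methoxy group. Nothing measured here gives a reason for the large step.

The compounds shown leave open whether a longer ether such as ethoxy, or an amine in place of the oxygen, would keep the effect of compound 3 or lose it as compound 4 does, and whether the same change would matter as much with phenoxy in place of dimethylamino. Among the compounds shown here, each value also comes from a single concentration, so the data show only that compound 3 has a stronger effect than compound 4 at that concentration, and say nothing of how the two compare at any other.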